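Truncating the chain amine of compound 1

A few compounds are considered here, and "the series" means these few. Any claim that something is new, unique, unknown or untested is made for them only; others in the source may bear on it.

Measured so far:
compound 1 `CN(C)CCCNc1nc(NCc2ccc(NC(=O)c3ccc(F)cc3)cc2)c2ccccc2n1` — 10000 nM
compound 2 `CN(C)CCCNc1nc(NCc2ccc(NC(=O)c3ccc(CN4CCN(C)CC4)cc3)cc2)c2ccccc2n1` — > 20000 nM

For the measured compounds named here, in a functional assay on HCT-116 cells (Homo sapiens) for inhibition, read by luminescence and resazurin assay, with a stated time of 3 days (on this read-out higher numbers stand for weaker inhibition and lower numbers for stronger inhibition), compound 1 gives 10000 nM, the only plain number in the set. For compound 2 this assay returns a limit rather than a number, > 20000 nM, as noted in the limit of > 20000 nM in this assay, at which 1 of the 2 values shown sits. Going by the values given here, the one measured step, an at least 2.0-fold higher number from compound 1 to compound 2 (0.30 log units; that floor lies within the scatter), alters a substituent on an aromatic carbon and sits at a floor within the scatter, so it says little about size or direction.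

Compound 3 `CCNc1nc(NCc2ccc(NC(=O)c3ccc(F)cc3)cc2)c2ccccc2n1` differs from compound 1 at a different place: hydrogen in place of (dimethylamino)methyl on a saturated chain carbon, two bonds along the chain from a nitrogen on an aromatic ring. No measured step touches this chain, so nothing shown bears directly on the change. The expectation is therefore a step no larger than the scatter, a 1.5-fold higher number from compound 1 to compound 3 (0.18 log units; within the scatter), leaning slightly toward weaker inhibition. Compound 3 is accordingly estimated at 15000 nM, between 5000 nM and 40000 nM, with a real chance that this assay again reports only a limit.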

Compound 3, half-maximal inhibitory concentration: 1400 nM
Compound 3: middle estimate off by 11-fold (1.03 log units), on the high side, outside the stated range (below it).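

The chain on the shared core is a position that matters: in this assay, replacing 3-(dimethylamino)propyl with ethyl gives a 7.1-fold lower number from compound 1 to compound 3 (0.85 log units; beyond the scatter). For the compounds shown here, this is the first step that can be read for both size and direction, since the only earlier step sat at a floor within the scatter. The (dimethylamino)methyl end of the chain is therefore not required for inhibition in these cells, and stronger inhibition is seen without it, although nothing shown accounts for the gain.

Still open, from the compounds shown here alone, is whether the gain follows from losing the terminal amine or from shortening the chain, which an unsubstituted propyl chain or a shorter chain ending in dimethylamino would separate. Also open, going by these compounds, is whether ethyl gives a similar step alongside the (4-methylpiperazin-1-yl)methyl group of compound 2, whose > 20000 nM is a limit.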